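The source may hold more compounds than are shown below. What is called first, only, known or untested is meant among the compounds shown, and "the series" means these compounds.

In a functional assay on DU-145 cells (Homo sapiens) for inhibition, read by trypan blue exclusion, with a stated time of 96 h (on this read-out lower numbers stand for stronger inhibition of growth and higher numbers for weaker inhibition of growth), compound 3 `Cc1cc(C)cc(/C=C(/SCc2ccc(Cl)cc2)C(=O)c2ccc(Cl)cc2)c1` gives 10000 nM and stands level with compound 2 `Cc1ccc(C)c(/C=C(/SCc2ccc(Cl)cc2)C(=O)c2ccc(Cl)cc2)c1` at 10000 nM on these numbers. Compound 1 `CSc1ccc(/C=C(/SCc2ccc(Cl)cc2)C(=O)c2ccc(C(=O)O)cc2)cc1` returns > 100000 nM as its result, which is a limit of the assay and not a number.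

Compound 4 `CSc1ccc(/C=C(/SCc2ccc(Cl)cc2)C(=O)c2ccc(Cl)cc2)cc1` keeps the rest of compound 3 and alters one group, with 4-(methylsulfanyl)phenyl in place of 3,5-dimethylphenyl on a double-bonded chain carbon bound to a double-bonded chain carbon. The count 4-(methylsulfanyl)phenyl in place of 3,5-dimethylphenyl on a double-bonded chain carbon bound to a double-bonded chain carbon sets out what leaves and what enters.

Among the measured compounds shown here, the one measured step at this place is no change at the digits printed from compound 2 to compound 3 (within the scatter) for 3,5-dimethylphenyl in place of 2,5-dimethylphenyl on that same carbon. That step only rearranges methyl groups, whereas compound 4 brings in a sulfur atom, so it is a loose guide. For the measured compounds named here, no measured step isolates this swap, and compound 1 does not supply one.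

Taking compound 3 at 10000 nM as the starting point, no step beyond the scatter is expected, and the estimated move is a 1.3-fold lower number from compound 3 to compound 4 (0.10 log units; within the scatter) with no firm direction. For compound 4 the expected value is 8000 nM, with an estimated range of 2000 nM to 30000 nM as its likely span.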

Compound 4, concentration for 50% growth inhibition: 25000 nM
Estimate against measurement, compound 4: 3.1-fold (0.49 log units) below, and the stated range covers the measured number.
By their numbers in this assay, from the lowest: compounds 2 and 3 (each within the scatter of the next); then compound 4. At a limit, above all of these: compound 1.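

In this assay, the group on the double-bonded chain carbon now proves able to shift the result, which the level pair of dimethylphenyl compounds could not show: bringing in 4-(methylsulfanyl)phenyl gives a 2.5-fold higher number from compound 3 to compound 4 (0.40 log units; beyond the scatter), and likewise a 2.5-fold higher number from compound 2 to compound 4 (0.40 log units; beyond the scatter), both toward weaker inhibition of growth. On these data alone, compound 4 also opens a comparison at a second place, where chloro in place of carboxy on an aromatic carbon gives an at least 4.0-fold lower number from compound 1 to compound 4 (0.60 log units; beyond the scatter), so the carboxy compound is the weaker of that pair by a margin whose full size stays unknown. Compound 1 gives > 100000 nM, which is a limit of the assay and not a number: the limit of > 100000 nM in this assay, at which 1 of the 4 values shown sits.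

What a plain phenyl or a 4-methoxyphenyl group would give on that chain carbon stays open, so the compounds shown cannot separate the effect of the sulfur atom from that of replacing the two methyl groups. As far as these compounds go, whether an amine on the aromatic carbon that holds chloro or carboxy would sit nearer compound 4 or compound 1 is also open.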